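The compounds below may be only part of what the source reports. "The series", "measured", "known", "first", "only" and "open" are said of these compounds alone.

Measured so far in a functional assay on MCF7 cells (Homo sapiens) for inhibition, read by sulforhodamine B assay; on this read-out higher numbers stand for weaker inhibition and lower numbers for stronger inhibition:
- compound 1, `O=C1C=C(Nc2ccc(I)cc2)C(=O)c2c1nc1n2[C@H]2OC[C@@H](O)[C@H]2OC1`: 2230 nM
- compound 2, `Cc1ccc(NC2=CC(=O)c3c(nc4n3[C@H]3OC[C@@H](O)[C@H]3OC4)C2=O)cc1C`: 4950 nM
- compound 3, `O=C1C(N2CCCCC2)=CC(=O)c2c1nc1n2[C@H]2OC[C@@H](O)[C@H]2OC1`: a limit of the assay, > 8000 nM

Compound 1 gives the lowest of the two numbers shown; compound 2 gives a higher number, and the gap between them is beyond the scatter. Among the measured compounds shown here, the only step measured between neighbours is an at least 1.6-fold higher number from compound 2 to compound 3 (0.20 log units; that floor lies within the scatter), where compound 3 reaches the limit of > 8000 nM in this assay, at which 1 of the 3 values shown sits, once the arylamino group is lost. Compound 4, `CCOc1ccccc1NC1=CC(=O)c2nc3n(c2C1=O)[C@H]1OC[C@@H](O)[C@H]1OC3`, keeps the arylamino group and changes only its aryl part: 2-ethoxyphenyl in place of 4-iodophenyl on an amine nitrogen. For the measured compounds named here, no measured step tests an exchange of one aryl group for another, so the bearing of the existing data is weak. Compound 1 and compound 2 show that such exchanges can move the number beyond the scatter. For compound 4 the expected step is therefore modest, a 1.6-fold higher number from compound 1 to compound 4 (0.20 log units; within the scatter), toward a somewhat higher number. Compound 4 is estimated at 3500 nM, between 1500 nM and 8000 nM.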

Compound 4, half-maximal inhibitory concentration: > 4000 nM
Compound 4: only a limit was reported; the forecaster's own chance of this, stated with the estimate: 12%; middle value at least 1.1-fold (0.05 log units) from the limit.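

Putting 2-ethoxyphenyl in place of 4-iodophenyl on the amine nitrogen gives an at least 1.7-fold higher number from compound 1 to compound 4 (0.25 log units; that floor lies within the scatter), the only aryl-for-aryl exchange here with a listed step in this assay. The value of compound 4 is a limit: the limit of > 4000 nM in this assay, at which 1 of the 4 values shown sits. Keeping the arylamino group therefore does not by itself hold the number at the level of compound 1, although the true size of this step cannot be read.

Going by these compounds, it stays open how 2-methoxyphenyl or 4-chlorophenyl on the same amine nitrogen would behave.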